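The source may report more compounds than this note shows. Statements on the series, on what has been measured and on what is new or still open speak of the compounds shown alone.

In a functional assay on KB cells (Homo sapiens) for antiproliferative activity, read by sulforhodamine B assay, with a stated time of 3 days (on this read-out higher numbers stand for an effect only at larger amounts of compound and lower numbers for an effect already at smaller amounts), compound 2 `CCC1=C(O)c2c(oc(-c3ccc(OC)cc3)cc2=O)C(CC)(CC)C1=O` gives 17.7 uM. Going by the values given here, compound 1 `CCC1=C(O)c2c(oc(-c3ccc(CC(C)C)cc3)cc2=O)C(CC)(CC)C1=O` gives 29.3 uM, and these are the only two true numbers in the set. The step between them, a 1.7-fold lower number from compound 1 to compound 2 (0.22 log units; within the scatter), places them level. Compound 3 `CCCOc1ccc(-c2cc(=O)c3c(o2)C(CC)(CC)C(=O)C(CC)=C3O)cc1` reads > 50.5 uM, which is a limit of the assay and not a number. Even so, the change on that side is an at least 2.8-fold higher number from compound 2 to compound 3 (0.45 log units; beyond the scatter), while the other comparison is an at least 1.7-fold higher number from compound 1 to compound 3 (0.23 log units; that floor lies within the scatter).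

Compound 4 `CCC1=C(O)c2c(oc(-c3cccc(C)c3)cc2=O)C(CC)(CC)C1=O` differs from compound 2 by 3-methylphenyl in place of 4-methoxyphenyl on an aromatic carbon. Among the compounds with values here, all the measured steps alter a group on this same aryl ring, but none of the measured compounds carries the 3-methylphenyl group, so they offer only indirect guidance. The nearest guide is the exchange of isobutyl for methoxy, a 1.7-fold lower number from compound 1 to compound 2 (0.22 log units; within the scatter), which suggests that an alkyl-for-ether swap can pass without a clear shift. Compound 3 goes against any general claim of tolerance, with an at least 2.8-fold higher number from compound 2 to compound 3 (0.45 log units; beyond the scatter).

In this assay, no change beyond the scatter is therefore expected, with a slight lean towards a higher number. The estimated step is a 1.4-fold higher number from compound 2 to compound 4 (0.13 log units; within the scatter). For compound 4 the expected value is 24 uM, with an estimated range of 11 uM to 52 uM.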

Compound 4, concentration for half-maximal effect: 49.7 uM
Compound 4: middle estimate off by 2.1-fold (0.32 log units), on the low side; the range from low to high includes it.
By their numbers in this assay, from the lowest: compounds 2, 1 and 4 (each within the scatter of the next, the first and the last beyond it). At a limit, above all of these: compound 3.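

In this assay, going by these compounds alone, the exchange of 4-methoxyphenyl for 3-methylphenyl on the aromatic carbon next to the ring oxygen gives a 2.8-fold higher number from compound 2 to compound 4 (0.45 log units; beyond the scatter), the first step beyond the scatter in this set that joins two true numbers. The earlier step between true numbers, a 1.7-fold lower number from compound 1 to compound 2 (0.22 log units; within the scatter), showed no clear shift, so the tolerance it hinted at does not extend to every change on this aryl group, and compound 4 now stands with compound 3 against any such reading. Compound 3 remains a limit and not a number, which leaves the top of this series without a true value: the limit of > 50.5 uM in this assay, at which 1 of the 4 values shown sits.

The step from compound 2 to compound 4 changes the substituent and its ring position together, so the shift cannot be assigned to either one alone; 4-methylphenyl and 3-methoxyphenyl would separate the two. Also open, on these data alone, is how this position responds to a substituent of another kind on the aryl ring, such as an amine or a carboxylic acid.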